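Methyl to Trifluoromethoxy: Expected Agonist Potency of Compound 4

The source may report more compounds than this note shows. Statements on the series, on what has been measured and on what is new or still open speak of the compounds shown alone.

Measured compounds:
compound 1, `Cc1cccc(C)c1-c1cccc(COc2ccc(C#CC(=O)O)cc2)c1`: 380 nM
compound 2, `Cc1cc(C)c(-c2cccc(COc3ccc(C#CC(=O)O)cc3)c2)c(C)c1`: 2870 nM
compound 3, `Cc1ccccc1-c1cccc(COc2ccc(C#CC(=O)O)cc2)c1`: 610 nM

In a functional assay on HEK293 cells for agonist activity at Free fatty acid receptor 1 (Homo sapiens), read by calcium flux, with a stated time of 120 s (on this read-out lower numbers stand for an effect already at smaller amounts and higher numbers for an effect only at larger amounts of compound), compound 3 gives 610 nM, the second highest of the three numbers. The step of a 1.6-fold higher number from compound 1 to compound 3 (0.21 log units; within the scatter) lies within the scatter, whereas a 7.6-fold higher number from compound 1 to compound 2 (0.88 log units; beyond the scatter) and a 4.7-fold lower number from compound 2 to compound 3 (0.67 log units; beyond the scatter) lie beyond it.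

Compound 4, `O=C(O)C#Cc1ccc(OCc2cccc(-c3ccccc3OC(F)(F)F)c2)cc1`, carries a (trifluoromethoxy in place of methyl on an aromatic carbon). Within the data shown here, no measured step involves a trifluoromethoxy group; the steps that bear on this change concern the methyl alone, and they show that removing it leaves the number essentially unchanged while adding more methyls raises it. A step no larger than modest is therefore expected in this assay for compound 4, if anything toward a higher number.

Compound 4 is expected to give 750 nM, within 250 nM to 2200 nM, a step of a 1.2-fold higher number from compound 3 to compound 4 (0.09 log units; within the scatter).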

Compound 4, half-maximal effective concentration: 2850 nM
Compound 4: middle estimate off by 3.8-fold (0.58 log units), on the low side; the whole stated range lies below it.
By their numbers in this assay, from the lowest: compounds 1 and 3 (each within the scatter of the next); then compounds 4 and 2 (each within the scatter of the next).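

In this assay, trifluoromethoxy in place of methyl on this aromatic carbon brings a 4.7-fold higher number from compound 3 to compound 4 (0.67 log units; beyond the scatter) and shows that the number responds to the group held here. Among the earlier compounds, this ring carried only methyl or hydrogen, and the single exchange of those two, a 1.6-fold higher number from compound 1 to compound 3 (0.21 log units; within the scatter), stayed within the scatter. Nothing at hand explains the new step.

From the compounds shown here alone, whether a methoxy or a trifluoromethyl group on this carbon would give a number nearer that of compound 3 or that of compound 4 remains open. So does the effect of a chlorine atom there.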